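Swapping a nitro for a fluoro on a weak antiproliferative

The compounds below may be only part of what the source reports. "The series", "measured", "known", "first", "only" and "open" are said of these compounds alone.

Measured so far:
compound 1 `O=[N+]([O-])c1ccccc1CSc1nnc(-c2ccc3c(c2)OCCO3)n1-c1ccccc1`: 69800 nM
compound 2 `O=[N+]([O-])c1ccc(CSc2nnc(-c3ccc4c(c3)OCCO4)n2-c2ccccc2)cc1`: 36200 nM

In a functional assay on HeLa cells (Homo sapiens) for antiproliferative activity, read by MTT assay, with a stated time of 24 h (on this read-out higher numbers stand for weaker inhibition and lower numbers for stronger inhibition), compound 1 gives 69800 nM, the highest of the two numbers; its nearest neighbour, compound 2, gives 36200 nM. The step of a 1.9-fold lower number from compound 1 to compound 2 (0.29 log units; within the scatter) moves the nitro group to another position on the ring and is within the scatter, so the two compounds show no difference that can be trusted.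

Compound 3 `Fc1ccccc1CSc1nnc(-c2ccc3c(c2)OCCO3)n1-c1ccccc1` has not been measured. It differs from compound 1 by fluoro in place of nitro on an aromatic carbon. Going by the values given here, no measured step covers this exchange; the only known step changes where the nitro sits, not what replaces it, and it was within the scatter. Compound 3 is therefore expected to give a number close to that of compound 1, with the step of a 1.2-fold lower number from compound 1 to compound 3 (0.07 log units; within the scatter) expected to lie within the scatter. The estimate for compound 3 is 60000 nM, with a range from 20000 nM to 180000 nM.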

Compound 3, half-maximal inhibitory concentration: 24300 nM
For compound 3 the middle estimate is 2.5-fold (0.39 log units) above the measured one, within the range that was stated.
By their numbers in this assay, from the lowest: compounds 3, 2 and 1 (each within the scatter of the next, the first and the last beyond it).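

The earlier compounds shown here only moved the nitro group around the ring, so they could not show whether this position responds to a change of group. In this assay it does: on the aromatic carbon ortho to a large group, fluoro in place of nitro gives a modest change beyond the scatter (a 2.9-fold lower number from compound 1 to compound 3 (0.46 log units; beyond the scatter)). The 2-fluorophenyl and 4-nitrophenyl compounds, however, cannot be told apart (a 1.5-fold lower number from compound 2 to compound 3 (0.17 log units; within the scatter)), and no supporting data explain the change seen at this position.

From the compounds shown here alone, it remains open whether the change depends on fluoro itself or on the loss of nitro, which a plain hydrogen at this position would help separate. A chloro, methoxy or amino group on the same carbon could show how much further this position can move the number.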